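The compounds below may be only part of what the source reports. "The series", "measured", "known", "first", "only" and "open" are said of these compounds alone.

The measured compounds:

compound 1, `Nc1nc(O)c2c(n1)n(C1OC(CO)[C@@H](O)[C@H]1O)c(=O)n2Cc1ccc(Cl)c(Cl)c1`, 0%
compound 2, `CCCn1c(=O)n(C2CCC(COC(C)=O)O2)c2nc(NC(C)=O)nc(O)c21`, 11%
compound 3, `COc1ccc(Cn2c(=O)n(C3OC(CO)[C@@H](O)[C@H]3O)c3nc(N)nc(O)c32)cc1`, 14%

All three numbers come from a functional assay on the whole organism with Mus musculus as the target; on this read-out higher numbers stand for larger maximal responses and lower numbers for smaller maximal responses. Among them the number for compound 3 is the top one, but compound 2 lies within the usual scatter of it, so the two cannot be told apart; only compound 1 sits beyond the scatter below compound 3.

Compound 4, `CCOC(=O)Cn1c(=O)n(C2OC(CO)[C@@H](O)[C@H]2O)c2nc(N)nc(O)c21`, has not yet been measured. It differs from compound 3 in a single place: ethoxycarbonyl in place of 4-methoxyphenyl on a saturated chain carbon bound to an aromatic nitrogen.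

For the measured compounds named here, one measured step bears on this position. The change from 3,4-dichlorophenyl to 4-methoxyphenyl on the same saturated chain carbon gave a number 14 percentage points higher from compound 1 to compound 3 (beyond the scatter), a modest shift, so the group here does move the read-out, but not by much. Going by the values given here, compound 2, which carries a different group at the corresponding place together with further changes elsewhere, gives 11% against 14% for compound 3; no single-change step links them. The incoming ethoxycarbonyl has no ring and is smaller than either aryl group seen so far, so the direction is uncertain. On balance a small decrease is expected for compound 4, a number 6 percentage points lower from compound 3 to compound 4 (within the scatter), within or barely beyond the scatter. The estimate for compound 4 is 8%, with a range from 0% to 20%.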

Compound 4, largest response reached (reported as maximal response), in percent of the reference or control that the assay uses: 58%
For compound 4 the middle estimate is 50 percentage points below the measured one; measured number outside the range, above it.
By their numbers in this assay, from the lowest: compound 1; then compounds 2 and 3 (each within the scatter of the next); then compound 4.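

In this assay, the group on the saturated chain carbon bound to an aromatic nitrogen can move the read-out much further than the two aryl groups alone had shown. Ethoxycarbonyl in place of 4-methoxyphenyl gives a number 44 percentage points higher from compound 3 to compound 4 (beyond the scatter), and ethoxycarbonyl in place of 3,4-dichlorophenyl gives a number 58 percentage points higher from compound 1 to compound 4 (beyond the scatter); both steps are large, whereas the exchange of one aryl group for the other, a number 14 percentage points higher from compound 1 to compound 3 (beyond the scatter), was modest, so at this place leaving the aryl groups for a group without a ring counts for more than the choice between those two aryl groups. No measurement available here accounts for this rise in the response.

For the compounds shown here, with ethoxycarbonyl as the only group without a ring among the compounds that differ at this place alone, it remains open whether the rise belongs to that whole group or would also appear with a carboxylic acid, a primary amide or a plain longer chain on the same carbon. From the compounds shown here alone, it is also open whether an aryl group carrying other substituents could come closer to compound 4 or whether the low numbers hold for aryl groups in general.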